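The source may report more compounds than this note shows. Statements on the series, on what has been measured and on what is new or still open speak of the compounds shown alone.

Working notes on the shared core. In a functional assay on HEK293 cells for negative allosteric modulation of metabotropic glutamate receptor 5 (Rattus norvegicus), read by FLIPR and calcium flux, with a stated time of 170 s (a lower number here means a stronger inhibitor, a higher number a weaker inhibitor), compound 1 `c1ccc(-c2cc3n(n2)CCCC3)nc1` gives 1290 nM, while compound 2 `O=C(Cc1ccccn1)c1cc2n(n1)CCCC2` gives 390 nM. Compound 3 `N#Cc1cccnc1NC(=O)c1cc2n(n1)CCCC2`, an amide with a cyano group on the pyridine ring, gives "not active" (no number reported) in this assay, so no number stands for it and nothing can be said of its place among the others beyond that. The step to compound 4 `Nc1cccnc1NC(=O)c1cc2n(n1)CCCC2` is amino in place of cyano on an aromatic carbon. Among the compounds with values here, no measured pair shows the effect of this change on this assay, and the absence of a number for compound 3 leaves no anchor. Compound 4 is therefore expected to be weak, with a considerable chance that this assay again reports no number; the estimate for compound 4 is 4000 nM, in a range from 600 nM to 30000 nM.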

Compound 4, half-maximal inhibitory concentration: > 10000 nM
Compound 4 ended at the assay's limit (the forecaster's own chance of this, stated with the estimate: 45%); middle value at least 2.5-fold (0.39 log units) from the limit.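

Compound 4 gives > 10000 nM in this assay, which is a limit and not a number. Within the data shown here, with no number for compound 3 either, no step to compound 4 can be read. The compounds shown leave open how amino and cyano compare on this amide.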